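The source may report more compounds than this note shows. Statements on the series, on what has been measured and on what is new or still open speak of the compounds shown alone.

Of the compounds shown here, three that share a core have been tested in a toxicity assay on GES1 cells (Homo sapiens) for inhibition, read by MTT assay, with a stated time of 72 h; a lower number here means a stronger inhibitor, a higher number a weaker inhibitor. Compound 1 `C[C@@H]1CCN(c2cc(-c3ccccc3)nc3ncnn23)C[C@@H]1N(C)c1ncnc2[nH]ccc12` reaches only a limit there, > 100000 nM. Compound 3 `CCCCCc1c(C)nc2nc(SCc3ccc(Cl)cc3)nn2c1N1CC[C@@H](C)[C@@H](N(C)c2ncnc3[nH]ccc23)C1` likewise gives only a limit, > 100000 nM. Among the measured compounds shown here, compound 2 `Cc1cc(N2CC[C@@H](C)[C@@H](N(C)c3ncnc4[nH]ccc34)C2)n2nc(SCc3ccc(F)cc3)nc2n1` is the one compound with a measured number, 12300 nM in this assay, and so it sits apart from the limit of > 100000 nM in this assay, at which 2 of the 3 values shown sit. Compound 4 `Cc1cc(N2CC[C@@H](C)[C@@H](N(C)c3ncnc4[nH]ccc34)C2)n2nc(SCc3ccc(C(F)(F)F)cc3)nc2n1` has not yet been measured. It differs from compound 2 in one place (trifluoromethyl in place of fluoro on an aromatic carbon). For the measured compounds named here, no measured pair shows what such a swap does in this assay, so the expected step is small, a 1.2-fold higher number from compound 2 to compound 4 (0.09 log units; within the scatter), not beyond the usual scatter. Compound 4 is therefore estimated at 15000 nM, with a range from 5000 nM to 50000 nM.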

Compound 4, half-maximal inhibitory concentration: 17300 nM
Estimate against measurement, compound 4: 1.2-fold (0.06 log units) below, within the range that was stated.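

In this assay, among the compounds shown here, trifluoromethyl in place of fluoro on an aromatic carbon gives a 1.4-fold higher number from compound 2 to compound 4 (0.15 log units; within the scatter), the first readable step at this position. Going from 4-fluorobenzyl to 4-(trifluoromethyl)benzyl therefore makes no difference beyond the scatter, even though the group entering is larger by heavy-atom count. Compound 2 and compound 4 both give a measured number, apart from the limit: the limit of > 100000 nM in this assay, at which 2 of the 4 values shown sit.

Going by these compounds, whether an amine or a carboxylic acid at this position would keep the number in the same range remains open. For the compounds shown here, compound 1 and compound 3 differ from compound 2 in more than one place, so no step to them can be read.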